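The source may hold more compounds than are shown below. What is called first, only, known or untested is meant among the compounds shown, and "the series" means these compounds.

Measured so far:
- compound 1 `CNC(=O)Nc1ccc(-c2nc(N3CC4CCC(C3)O4)c3cnn(CCN(C)C)c3n2)cc1`: 400 nM
- compound 2 `O=C(Nc1ccncc1)Nc1ccc(-c2nc(N3CC4CCC(C3)O4)c3cnn(C4CCC5(CC4)OCCO5)c3n2)cc1`: 1 nM

In a functional assay on LNCaP cells (Homo sapiens) for cytotoxicity (a lower number here means a stronger inhibitor, a higher number a weaker inhibitor), compound 1 stands highest of the two at 400 nM, and compound 2 gives 1 nM. The gap between these two compounds lies beyond the scatter. Compound 3 `CNC(=O)Nc1ccc(-c2nc(N3CC4CCC(C3)O4)c3cnn([C@H]4CC[C@@H](OC)CC4)c3n2)cc1` keeps the rest of compound 1 and carries 4-methoxycyclohexyl in place of 2-(dimethylamino)ethyl on an aromatic nitrogen. Among the measured compounds shown here, no measured pair isolates a change at this place, so any expectation is loose. For the measured compounds named here, the only guide is compound 2 at 1 nM, which also bears a six-membered non-aromatic ring on that nitrogen but differs elsewhere too. A move to a lower number, beyond the scatter, is expected in this assay, with the estimated step of a 6.7-fold lower number from compound 1 to compound 3 (0.82 log units; beyond the scatter). For compound 3 the estimated value is 60 nM, with an expected range of 12 nM to 300 nM.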

Compound 3, half-maximal inhibitory concentration: 1 nM
Compound 3: the middle estimate sits 60-fold (1.78 log units) above what was measured; the measured number lies below the stated range.
By their numbers in this assay, from the lowest: compounds 2 and 3 (each within the scatter of the next); then compound 1.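

In this assay this aromatic nitrogen proves to be a highly sensitive place in the series: 4-methoxycyclohexyl in place of 2-(dimethylamino)ethyl gives a 400-fold lower number from compound 1 to compound 3 (2.60 log units; beyond the scatter) and is a large step. Among the compounds shown here, compound 1 and compound 3 form the first pair that differs in this one place, so a change here alone, with the rest of the structure held constant, is enough to move the number well beyond the scatter. No available measurement accounts for the size of this step.

The swap alters several things together, including the six-membered non-aromatic ring, the chain nitrogen, the methoxy oxygen and the two defined stereocentres, and this one pair cannot separate them. Open questions are how an unsubstituted cyclohexyl, a 4-hydroxycyclohexyl or a 4-(dimethylamino)cyclohexyl would compare, and how the opposite stereoisomer of 4-methoxycyclohexyl would behave.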